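The compounds below may be only part of what the source reports. "The series", "measured", "known", "first", "only" and "open" are said of these compounds alone.

In a physicochemical assay for solubility, read by spectrophotometry, in phosphate buffer, with a stated time of 2 h, at pH 7.4 (on this read-out higher numbers stand for higher solubility and lower numbers for lower solubility), compound 1 `COc1ccc2[nH]c(C(=O)N3CC(=O)N(Cc4ccccc4)[C@@H](N4[C@H](C)CCC[C@@H]4C)C3)cc2c1` gives 100000 nM. Compound 2 `COc1ccc2[nH]c(C(=O)N3CC(=O)N(Cc4ccccc4)[C@@H](CN4[C@H](C)COC[C@@H]4C)C3)cc2c1` gives > 100000 nM, which is a limit of the assay and not a number. Going by the values given here, the only measured step, a number no lower from compound 1 to compound 2 (the limit leaves the size open), replaces 2,6-dimethylpiperidin-1-yl with (3,5-dimethylmorpholin-4-yl)methyl, so its size offers no firm guide.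

Compound 3 `COc1ccc2[nH]c(C(=O)N3CC(=O)N(Cc4ccccc4)[C@@H](CN4CCC(C(C)C)CC4)C3)cc2c1` changes compound 2 on a saturated chain carbon bound to a saturated ring carbon: 4-isopropylpiperidin-1-yl in place of 3,5-dimethylmorpholin-4-yl on a saturated chain carbon bound to a saturated ring carbon. The entering 4-isopropylpiperidin-1-yl has no ring oxygen. The closest comparison is therefore compound 1, also a piperidine without ring oxygen, at 100000 nM. On that basis, a modest downward move in this assay is expected, though it may not clear the usual scatter. The expected change is an at least 1.6-fold lower number from compound 2 to compound 3 (0.22 log units; that floor lies within the scatter). Compound 3 is estimated at 60000 nM, with an expected range of 20000 nM to 100000 nM.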

Compound 3, solubility: 12000 nM
The estimate for compound 3 lay 5.0-fold (0.70 log units) above the measured number, and the stated range ends above it.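

In this assay, going by these compounds alone, putting 4-isopropylpiperidin-1-yl in place of 3,5-dimethylmorpholin-4-yl on a saturated chain carbon bound to a saturated ring carbon gives an at least 8.3-fold lower number from compound 2 to compound 3 (0.92 log units; beyond the scatter), the first step with a readable size and a direction downward. Compound 2 gives a limit and not a number, so this size is only a floor: the limit of > 100000 nM in this assay, at which 1 of the 3 values shown sits. The 2,6-dimethylpiperidin-1-yl group also has no ring oxygen, yet replacing it with (4-isopropylpiperidin-1-yl)methyl on a saturated ring carbon still gives an 8.3-fold lower number from compound 1 to compound 3 (0.92 log units; beyond the scatter), so the absence of a ring oxygen alone does not set the number.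

The loss of the ring oxygen and the arrival of the isopropyl group happen together in the one step, and the compounds shown do not separate them. On these data alone, how a plain morpholin-4-yl group at this place would read remains open.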